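The source may report more compounds than this note shows. Statements on the series, on what has been measured and on what is new or still open speak of the compounds shown alone.

Compounds measured so far:
compound 1 `O=C1N=C(N2CCC[C@H]2C(=O)Nc2ccc3ncnc(Nc4cccc(Cl)c4)c3c2)S/C1=C/c1ccc(Br)s1` — > 50000 nM
compound 2 `O=C1N=C(N2CCC[C@H]2C(=O)Nc2ccc3ncnc(Nc4cccc(Cl)c4)c3c2)S/C1=C/c1cccnc1` — 8500 nM
compound 3 `O=C1N=C(N2CCC[C@H]2C(=O)Nc2ccc3ncnc(Nc4cccc(Cl)c4)c3c2)S/C1=C/c1cccs1` — 4120 nM

Of the compounds shown here, three sharing one core have been tested in a functional assay on HepG2 cells (Homo sapiens) for antiproliferative activity, read by MTT assay; on this read-out higher numbers stand for weaker inhibition and lower numbers for stronger inhibition. For compound 1 the result is a limit of the assay, (the limit of > 50000 nM in this assay, at which 1 of the 3 values shown sits), and not a number. Compound 2 gives 8500 nM and compound 3 gives 4120 nM; the step of a 2.1-fold lower number from compound 2 to compound 3 (0.31 log units; beyond the scatter) is modest but beyond the scatter. Among the two numbers known, compound 2 stands highest, with compound 3 as its nearest neighbour.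

Compound 4 `O=C1N=C(N2CCC[C@H]2C(=O)Nc2ccc3ncnc(Nc4cccc(Cl)c4)c3c2)S/C1=C/c1ccccc1F` is not yet measured. It differs from compound 2 as follows: 2-fluorophenyl in place of pyridin-3-yl on a double-bonded chain carbon bound to a double-bonded ring carbon. The step that bears most directly on this change is a 2.1-fold lower number from compound 2 to compound 3 (0.31 log units; beyond the scatter), where a five-membered ring with a hetero atom replaced the pyridin-3-yl; the change to 2-fluorophenyl also removes the hydrogen-bond acceptor of compound 2, so in this assay a modest lowering of the number is expected for compound 4, of the order of a 1.7-fold lower number from compound 2 to compound 4 (0.23 log units; within the scatter). Compound 4 is estimated at 5000 nM, with a range from 2000 nM to 15000 nM.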

Compound 4, half-maximal inhibitory concentration: 18200 nM
Beside the measured number, compound 4's estimate is 3.6-fold (0.56 log units) below it; measured number outside the range, above it.
By their numbers in this assay, from the lowest: compound 3; then compound 2; then compound 4. At a limit, above all of these: compound 1.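

In this assay, among the compounds shown here, this place on the double-bonded chain carbon proves sensitive to a six-membered ring of carbon only, which the earlier compounds did not show: replacing pyridin-3-yl with 2-fluorophenyl gives a 2.1-fold higher number from compound 2 to compound 4 (0.33 log units; beyond the scatter), and replacing thiophen-2-yl gives a 4.4-fold higher number from compound 3 to compound 4 (0.65 log units; beyond the scatter). The change to 2-fluorophenyl therefore ranks behind both of these rings, while the order among all three stays beyond the scatter. Compound 1 is a limit of the assay and not a number, so its step to 2-fluorophenyl reads only as a bound, an at least 2.7-fold lower number from compound 1 to compound 4 (0.43 log units; beyond the scatter): the limit of > 50000 nM in this assay, at which 1 of the 4 values shown sits.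

The compounds shown leave open whether the higher number belongs to the fluorine or to the carbon-only ring itself, which plain phenyl would separate. From the compounds shown here alone, how a methoxy group or an amine on that phenyl ring would read also remains open.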